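Swapping Fluoro for Bromo on a Uracil Nucleoside Core

The source may hold more compounds than are shown below. What is called first, only, known or untested is meant among the compounds shown, and "the series" means these compounds.

Compound 1 `O=c1[nH]c(=O)n([C@H]2C[C@@H]3O[PH](O)(O)OC[C@H]3O2)cc1F` is the reference. In a functional assay on L1210 cells (Mus musculus) for antiproliferative activity (on this read-out lower numbers stand for stronger inhibition and higher numbers for weaker inhibition), compound 1 gives 7.4 ug/mL, the lowest of the two numbers shown. Compound 3 `O=c1[nH]c(=O)n([C@H]2C[C@H](O)[C@@H](COP(=O)(O)O)O2)cc1C(F)(F)F` gives 38 ug/mL in this assay, a gap beyond the usual scatter. Compound 2 `O=c1[nH]c(=O)n([C@H]2C[C@@H]3OP(=O)(OCc4ccccc4)OC[C@H]3O2)cc1I` reaches only a limit of this assay, > 100 ug/mL, not a number (the limit of > 100 ug/mL in this assay, at which 1 of the 3 values shown sits). Compound 4 `O=c1[nH]c(=O)n([C@H]2C[C@@H]3O[PH](O)(O)OC[C@H]3O2)cc1Br` is not yet measured; it differs from compound 1 by bromo in place of fluoro on an aromatic carbon. Going by the values given here, no measured pair shows this same change, so its size is open. Since compound 3, bearing trifluoromethyl, gives 38 ug/mL, a weakening is expected, and the step of a 4.1-fold higher number from compound 1 to compound 4 (0.61 log units; beyond the scatter) is estimated to lie beyond the scatter. Compound 4 is therefore expected to give about 30 ug/mL, in the range 6 ug/mL to 150 ug/mL.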

Compound 4, concentration for 50% inhibition: > 1000 ug/mL
Compound 4 ended at the assay's limit (the forecaster's own chance of this, stated with the estimate: 25%); middle value at least 33-fold (1.52 log units) from the limit.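

In this assay, bromo in place of fluoro gives an at least 130-fold higher number from compound 1 to compound 4 (2.13 log units; beyond the scatter), the first single change read at this aromatic carbon. On the core of compound 1, the read-out therefore depends strongly on whether fluoro or bromo sits there. Compound 4 stands at a limit of the assay and not at a number, so the true size of the step stays unknown: the limit of > 1000 ug/mL in this assay, at which 1 of the 4 values shown sits.

As far as these compounds go, how chloro, methyl or an amine at this place would read remains open. From the compounds shown here alone, whether the same swap gives a step of this size on another core also remains open.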